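Cyclopropyl for 4-Methylphenyl on the Ring Amide Nitrogen

The source may report more compounds than this note shows. Statements on the series, on what has been measured and on what is new or still open speak of the compounds shown alone.

Compound 1 `COc1ncc(-c2ccc3c(c2)N(c2ccc(C)cc2)C(=O)CO3)cc1NS(=O)(=O)c1ccc(F)cc1`: 22700 nM
Compound 2 `Cc1ccc(N2C(=O)COc3ccc(-c4cnc(Cl)c(NS(=O)(=O)c5ccc(F)cc5)c4)cc32)cc1`: 34300 nM
Compound 3 `O=C1COc2ccc(-c3cccc(NS(=O)(=O)c4ccc(F)cc4)c3)cc2N1c1ccc(F)cc1`: > 40000 nM, a limit of the assay

Three compounds sharing one core were tested in a functional assay on HCT-116 cells (Homo sapiens) for antiproliferative activity, read by MTT assay, with a stated time of 72 h; on this read-out higher numbers stand for weaker inhibition and lower numbers for stronger inhibition. Compound 1 gives the lowest of the two numbers, and compound 2 lies nearest, with a 1.5-fold higher number from compound 1 to compound 2 (0.18 log units; within the scatter). For compound 3 only a limit is recorded, (the limit of > 40000 nM in this assay, at which 1 of the 3 values shown sits). Compound 4 `COc1ncc(-c2ccc3c(c2)N(C2CC2)C(=O)CO3)cc1NS(=O)(=O)c1ccc(F)cc1` has not yet been measured; it differs from compound 1 by cyclopropyl in place of 4-methylphenyl on an amide-type nitrogen in a ring. Among the compounds with values here, the only measured step concerns a different place on the core, so no step bears directly on this change, and no direction can be read from the data. Compound 4 is therefore expected to show a 1.3-fold higher number from compound 1 to compound 4 (0.12 log units; within the scatter), a step not expected to pass beyond the scatter, and its estimated value is 30000 nM, with a range from 10000 nM to 90000 nM.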

Compound 4, half-maximal inhibitory concentration: 24300 nM
For compound 4 the middle estimate is 1.2-fold (0.09 log units) above the measured one, and the stated range covers the measured number.
By their numbers in this assay, from the lowest: compounds 1, 4 and 2 (each within the scatter of the next). At a limit, above all of these: compound 3.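

Within the data shown here, this is the first reading at the amide-type nitrogen in a ring: in this assay, cyclopropyl in place of 4-methylphenyl gives a 1.1-fold higher number from compound 1 to compound 4 (0.03 log units; within the scatter) on the core of compound 1. On that core, then, the six-membered aromatic ring at this nitrogen can give way to a three-membered carbon ring without a step beyond the scatter. Nothing shown bears on the reason for this.

From the compounds shown here alone, whether an amine, a carboxylic acid or a longer chain on this nitrogen would give a step beyond the scatter stays open. So does whether cyclopropyl behaves the same way on the core of compound 2.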